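The source may hold more compounds than are shown below. What is called first, only, known or untested is meant among the compounds shown, and "the series" means these compounds.

Working notes on the series.

Compound 1 `Cn1c(=O)c(S(=O)(=O)Cc2ccc(F)cc2F)cc2cnc(Nc3ccc4[nH]ccc4c3)nc21` is the reference point. In a functional assay on K562 cells (Homo sapiens) for inhibition, read by trypan blue exclusion, with a stated time of 72 h (on this read-out higher numbers stand for weaker inhibition and lower numbers for stronger inhibition), compound 1 gives 1000 nM, the lowest of the two numbers recorded so far. For the measured compounds named here, compound 2 `Cn1c(=O)c(S(=O)(=O)c2ccc(F)cc2F)cc2cnc(Nc3ccc4c(c3)CC(=O)N4)nc21` differs from compound 1 at more than one place, so no single step connects them; in this assay compound 2 gives 15000 nM, a higher number that lies beyond the scatter of compound 1.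

Compound 3 `Cn1c(=O)c(S(=O)(=O)c2ccc(F)cc2N)cc2cnc(Nc3ccc4[nH]ccc4c3)nc21` is not yet measured. Going by the values given here, its only departure from compound 1 is 2-amino-4-fluorophenyl in place of 2,4-difluorobenzyl on a sulfonyl sulfur. The sulfonyl sulfur keeps its other neighbour, an aromatic carbon, and the shared core and the remainder of compound 1 are unchanged.

Among the compounds with values here, no measured pair isolates this change, so the expected step is set by judgement rather than by a recorded step. The step expected from compound 1 to compound 3 in this assay is a 2.5-fold higher number from compound 1 to compound 3 (0.40 log units; beyond the scatter), a modest rise in the number that may fall within the scatter. Compound 3 is expected to give about 2500 nM in this assay, within a range from 600 nM to 10000 nM.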

Compound 3, half-maximal inhibitory concentration: 2000 nM
Beside the measured number, compound 3's estimate is 1.3-fold (0.10 log units) above it; the measured number falls inside the stated range.
By their numbers in this assay, from the lowest: compounds 1 and 3 (each within the scatter of the next); then compound 2.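

For the compounds shown here, the only single-place step so far, in this assay, is a 2.0-fold higher number from compound 1 to compound 3 (0.30 log units; within the scatter) for 2-amino-4-fluorophenyl in place of 2,4-difluorobenzyl on a sulfonyl sulfur. This position therefore accepts a change of the whole group with no shift beyond the scatter, even though the entering group carries a hydrogen-bond donor and a hydrogen-bond acceptor and the leaving group carries neither. No measured evidence accounts for this result.

The compounds shown leave open what the amino group and the loss of the benzyl carbon each contribute, a question that 2,4-difluorophenyl or 2-amino-4-fluorobenzyl on the core of compound 1 would separate. Also open, on these data alone, is how a carboxylic acid or a longer alkyl chain on the sulfonyl sulfur would read out.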